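A few compounds are considered here, and "the series" means these few. Any claim that something is new, unique, unknown or untested is made for them only; others in the source may bear on it.

Measured compounds, in an assay on HEK293 cells for displacement of a labelled ligand from Urotensin-2 receptor (Homo sapiens); on this read-out lower numbers stand for stronger inhibition and higher numbers for weaker inhibition:
compound 1 `Cn1cnc2c(NC(=O)NCCN3CCC(O)(Cc4ccccc4)CC3)ccnc21` gives 2140 nM
compound 2 `O=C(NCCN1CCC(O)(Cc2ccccc2)CC1)Nc1ccnc2ccoc12` gives 450 nM

Among the measured compounds shown here, compound 2 has the lower of the two numbers; its only neighbour is compound 1, with a 4.8-fold lower number from compound 1 to compound 2 (0.68 log units; beyond the scatter). Compound 3 `O=C(NCCN1CCC(O)(Cc2ccccc2)CC1)Nc1ccnc2c(Br)csc12` differs from compound 2 by a group of 10 heavy atoms (7 carbon, 1 nitrogen, 1 sulfur, 1 bromine; one five-membered aromatic ring with 1 hetero atom, one six-membered aromatic ring with 1 hetero atom) in place of a group of 9 heavy atoms (7 carbon, 1 nitrogen, 1 oxygen; one five-membered aromatic ring with 1 hetero atom, one six-membered aromatic ring with 1 hetero atom), on an amide-type nitrogen. For the measured compounds named here, no measured step covers this exchange; the single step from compound 1 to compound 2 shows that changing this ring pair can shift the read-out beyond the scatter, in either direction. For compound 3 a step of a 1.5-fold lower number from compound 2 to compound 3 (0.18 log units; within the scatter) is expected, near the scatter. Compound 3 is thus estimated at 300 nM, range 100 nM to 1000 nM.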

Compound 3, half-maximal inhibitory concentration: 3220 nM
For compound 3 the middle estimate is 11-fold (1.03 log units) below the measured one, and the stated range ends below it.
By their numbers in this assay, from the lowest: compound 2; then compounds 1 and 3 (each within the scatter of the next).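

In this assay, exchanging the group on the amide-type nitrogen can also raise the number: a 7.2-fold higher number from compound 2 to compound 3 (0.85 log units; beyond the scatter), so the earlier downward step sets no general direction for this position. With a 1.5-fold higher number from compound 1 to compound 3 (0.18 log units; within the scatter), two different ring pairs lie within the scatter of each other, and among the three compounds only the ring pair of compound 2 stands apart. Nothing available explains the step to the group with sulfur and bromine.

Sulfur and bromine enter together, so their separate shares in the step remain open. A methyl or chlorine in place of the bromine would be an informative comparison.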